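Replacing a Dichlorophenyl Amide with a Dichloromethyl Amide

The source may hold more compounds than are shown below. What is called first, only, known or untested is meant among the compounds shown, and "the series" means these compounds.

Measured compounds:
compound 1 `O=C(CSc1nnc(NC(=O)c2c(Cl)cccc2Cl)s1)Nc1ccc(Br)cn1`, 16800 nM
compound 2 `COc1ccccc1C(=O)Nc1nnc(SCC(=O)Nc2ccc(Cl)cn2)s1`, > 80000 nM
compound 3 `O=C(CSc1nnc(NC(=O)CCl)s1)Nc1ccc(Cl)cn1`, 5700 nM

All three share one core and were tested in a functional assay on NCI-H460 cells (Homo sapiens) for antiproliferative activity, read by MTT assay, with a stated time of 48 h; on this read-out higher numbers stand for weaker inhibition and lower numbers for stronger inhibition. Compound 1 gives 16800 nM, the highest of the two actual numbers. Compound 3 gives 5700 nM, a lower number than compound 1. For compound 2 the result is only a limit of the assay, > 80000 nM, not a number (the limit of > 80000 nM in this assay, at which 1 of the 3 values shown sits). Among the compounds with values here, the single comparable step is an at least 14-fold lower number from compound 2 to compound 3 (1.14 log units; beyond the scatter), where a small chlorinated group took the place of an aromatic ring on the carbonyl carbon.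

Compound 4 `O=C(CSc1nnc(NC(=O)C(Cl)Cl)s1)Nc1ccc(Br)cn1` differs from compound 1 by dichloromethyl in place of 2,6-dichlorophenyl on a carbonyl carbon. This is the same kind of exchange, aryl leaving and a chlorinated methyl group entering on the carbonyl carbon. A lower number is therefore expected for compound 4 because the step of an at least 14-fold lower number from compound 2 to compound 3 (1.14 log units; beyond the scatter) was large in that direction, though compound 1 starts from a lower number than compound 2 did, so the gain is estimated to be smaller. Compound 4 is expected at 5000 nM, between 1500 nM and 18000 nM. That corresponds to an expected step of a 3.4-fold lower number from compound 1 to compound 4 (0.53 log units; beyond the scatter).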

Compound 4, half-maximal inhibitory concentration: 5300 nM
For compound 4 the middle estimate is 1.1-fold (0.03 log units) below the measured one; the range from low to high includes it.
By their numbers in this assay, from the lowest: compounds 4 and 3 (each within the scatter of the next); then compound 1. At a limit, above all of these: compound 2.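

On this carbonyl carbon, an aromatic ring gives way to a small chlorinated group in a step with a true number at both ends: a 3.2-fold lower number from compound 1 to compound 4 (0.50 log units; beyond the scatter). The earlier step of this kind started from compound 2, whose result is only a limit of the assay, > 80000 nM. Both exchanges now point the same way, with no pair shown going against them, even though the two pairs carry different aromatic rings and different chlorinated methyl groups.

Nothing shown here explains why the smaller group gives the lower number. Also open, on these data alone, is how the number would respond to a plain methyl group, an aminomethyl group or a longer chain, such as chloropropyl, on this carbonyl carbon, none of which carries the chlorinated methyl group of compound 4.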